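This account rests on a few compounds, and the source may have more. Where it says the series, first, only, none or still open, it means among the compounds named here.

Going by the values given here, compound 2, whose structure is `COc1ccc(Cl)cc1-n1ncc(-c2nnc(-c3ccc(C)c([N+](=O)[O-])c3)o2)c1C`, stands at the top of the two numbers measured so far: in a physicochemical assay for lipophilicity, using the shake flask method, measured as octanol-water partition (on this read-out lower numbers stand for lower lipophilicity and higher numbers for higher lipophilicity), compound 2 gives 6.42, and compound 1, with structure `COc1ccc(Cl)cc1-n1ncc(-c2nnc(-c3cccc(F)c3)o2)c1C`, gives 4.28 in this assay. Among the compounds with values here, the one measured step between them, a number 2.14 log units higher from compound 1 to compound 2 (beyond the scatter), is the only step that bears on the change now considered. Compound 3, with structure `COc1ccc(Cl)cc1-n1ncc(-c2nnc(-c3ccc(F)cc3)o2)c1C`, differs from compound 2 by 4-fluorophenyl in place of 4-methyl-3-nitrophenyl on an aromatic carbon. This change undoes the methyl and nitro substitution that separates compound 1 from compound 2 and returns to a fluorophenyl group, so a large drop of roughly the size seen from compound 1 to compound 2 is expected, in the opposite direction, as a number 2.12 log units lower from compound 2 to compound 3 (beyond the scatter). On that basis compound 3 is estimated to give 4.3 in this assay, within a range from 3.7 to 4.9.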

Compound 3, partition coefficient: 4.26
For compound 3 the middle estimate is 0.04 log units above the measured one; low and high end bracket the measured number.
By their numbers in this assay, from the lowest: compounds 3 and 1 (each within the scatter of the next); then compound 2.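

In this assay the change to 4-fluorophenyl gives a number 2.16 log units lower from compound 2 to compound 3 (beyond the scatter) and so shows that the high number of compound 2 does not carry over to a second fluorophenyl compound. The change from 3-fluorophenyl to 4-fluorophenyl gives a number 0.02 log units lower from compound 1 to compound 3 (within the scatter) and so shows that these two fluorophenyl groups cannot be told apart on this aromatic carbon in this read-out. Nothing available here bears on why the step away from 4-methyl-3-nitrophenyl is so large.

The compounds shown leave open whether the methyl, the nitro or the two together account for the high number of compound 2, since that group holds both. They also leave open how this position would read with an amine or a carboxylic acid on the phenyl ring.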